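This account rests on a few compounds, and the source may have more. Where it says the series, first, only, none or still open, it means among the compounds named here.

Compound 1 `CCOc1ccc2nc(C(=O)Nc3c(F)cc(-c4cccc(F)c4)cc3F)c(C)c(O)c2c1` gives 2.96% in a functional assay on A-375 cells (Homo sapiens) for antiproliferative activity, read by MTT assay, with a stated time of 24 h, tested at 1.23 ug/mL; a higher number here means a stronger effect of the compound at the concentration tested, a lower number a weaker effect.
Compound 2 `Cc1c(C(=O)Nc2c(F)cc(-c3cccc(F)c3)cc2F)nc2ccc(OC(F)(F)F)cc2c1O` gives 1.57% in this assay.
Compound 3 `COc1ccc2nc(C(=O)Nc3ccc(-c4ccccc4)cc3)c(C)c(O)c2c1` gives 18.7% in this assay.

Compound 3 thus stands highest of the three, beyond the scatter from both compound 1 and compound 2. The next compound, compound 4 `Cc1c(C(=O)Nc2ccc(-c3ccccc3)cc2)nc2ccccc2c1O`, differs from compound 3 in one place: hydrogen in place of methoxy on an aromatic carbon. Among the compounds with values here, no measured step removes a group at this place. Within the data shown here, the only single-point step, a number 1.4 percentage points lower from compound 1 to compound 2 (within the scatter), swaps one group on an oxygen for another and stays within the scatter, which says little about losing the oxygen entirely. Compound 1 and compound 2, both low, differ from compound 3 in more than one place, so the change is hard to read. A modest drop is expected, a number 6.7 percentage points lower from compound 3 to compound 4 (within the scatter), within a wide band; compound 4 is estimated at 12%, between 2% and 26%.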

Compound 4, a percentage reported as inhibition, at one concentration (the size of the read-out at that concentration, not a potency): 4.56%
Compound 4: middle estimate off by 7.4 percentage points, on the high side, and the stated range covers the measured number.
By their numbers in this assay, from the lowest: compounds 2, 1 and 4 (each within the scatter of the next); then compound 3.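

Replacing methoxy with hydrogen on this aromatic carbon gives, in this assay, a number 14.1 percentage points lower from compound 3 to compound 4 (beyond the scatter) when the rest of the structure stays the same. Unlike the earlier swap of one group on an oxygen for another, this step removes the oxygen itself and moves the read-out beyond the scatter, so this position matters for the effect seen at this concentration. Nothing measured here explains the size of this drop.

From the compounds shown here alone, it remains open how an amine, a chlorine atom or a longer chain on the oxygen would compare at this carbon. Going by these compounds, whether the step would have a similar size with a different amide part also remains open.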